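Swapping a Hydrogen for Fluorine on the Benzyl Ring

The source may hold more compounds than are shown below. What is called first, only, known or untested is meant among the compounds shown, and "the series" means these compounds.

Of the compounds shown here, three sharing one core have been measured. Compound 1 `O=[N+]([O-])c1cc(C(F)(F)F)cc([N+](=O)[O-])c1Oc1ccc(Cl)cc1/C=N\OCc1ccccc1` gives 1220 nM in a functional assay on MCF7 cells (Homo sapiens) for antiproliferative activity, read by MTT assay, with a stated time of 48 h; on this read-out lower numbers stand for stronger inhibition and higher numbers for weaker inhibition. Compound 2 `O=[N+]([O-])c1cc(C(F)(F)F)cc([N+](=O)[O-])c1Oc1ccc(Cl)cc1/C=N\OCc1ccccc1F` differs from compound 1 by fluoro in place of hydrogen on an aromatic carbon; in this assay compound 2 gives 1110 nM, and the step is a 1.1-fold lower number from compound 1 to compound 2 (0.04 log units; within the scatter). Compound 3 `O=[N+]([O-])c1cc(C(F)(F)F)cc([N+](=O)[O-])c1Oc1ccc(Br)cc1/C=N\OCc1ccccc1` differs from compound 1 by bromo in place of chloro on an aromatic carbon; in this assay compound 3 gives 1150 nM, and that step is a 1.1-fold lower number from compound 1 to compound 3 (0.03 log units; within the scatter).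

Compound 4 `O=[N+]([O-])c1cc(C(F)(F)F)cc([N+](=O)[O-])c1Oc1ccc(Br)cc1/C=N\OCc1ccccc1F` has not yet been measured. It differs from compound 3 by fluoro in place of hydrogen on an aromatic carbon, the same change that turns compound 1 into compound 2, made here on the core of compound 3.

The expected step from compound 3 to compound 4 is a 1.1-fold lower number from compound 3 to compound 4 (0.04 log units; within the scatter), placed beside a 1.1-fold lower number from compound 1 to compound 2 (0.04 log units; within the scatter), because a 1.1-fold lower number from compound 1 to compound 2 (0.04 log units; within the scatter) shows this change leaving the number essentially where it was. The core change from compound 1 to compound 3 also moved little, so compound 4 is expected to sit close to compound 3. Compound 4 is therefore estimated at 1050 nM, with the range 600 nM to 1900 nM reflecting the usual scatter.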

Compound 4, half-maximal inhibitory concentration: 1120 nM
The estimate for compound 4 lay 1.1-fold (0.03 log units) below the measured number; low and high end bracket the measured number.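

Putting fluoro in place of hydrogen on the core of compound 3 gives a 1.0-fold lower number from compound 3 to compound 4 (0.01 log units; within the scatter) in this assay, and this step agrees with the one made on the core of compound 1: the same change on two cores in this assay, a 1.1-fold lower number (0.04 log units; within the scatter) from compound 1 to compound 2 and a 1.0-fold lower number (0.01 log units; within the scatter) from compound 3 to compound 4, 1.1-fold (0.03 log units) apart, within the scatter of two such steps Bromo in place of chloro, read on the compounds that carry the 2-fluorobenzyl group, gives a 1.0-fold higher number from compound 2 to compound 4 (0.00 log units; within the scatter), and this step also agrees with its earlier counterpart: the same change on two cores in this assay, a 1.1-fold lower number (0.03 log units; within the scatter) from compound 1 to compound 3 and a 1.0-fold higher number (0.00 log units; within the scatter) from compound 2 to compound 4, 1.1-fold (0.03 log units) apart, within the scatter of two such steps Both changes therefore carry across these two cores with no measurable effect, but this does not show that a change with a real effect on the number would carry across in the same way, since no step among these four compounds lies beyond the scatter.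

The compounds shown leave open what a group other than fluoro on the benzyl ring, such as methoxy or an amine, would do to the number. They also leave open whether a carboxylic acid in place of the chloro or bromo would move it, and whether such a step would repeat from one core to another.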